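Swapping phenyl for butyl on the shared core

The compounds below may be only part of what the source reports. "The series", "measured", "known", "first", "only" and "open" are said of these compounds alone.

Read in an ADME assay on liver for metabolic stability, with Liver microsome (Homo sapiens) as the target, read by LC-MS, using microsomes (on this read-out lower numbers stand for slow clearance and higher numbers for fast clearance), the measured compounds are
Compound 1 `O=C(NCc1cc(Cl)ccc1-n1cnnn1)[C@@H]1C[C@H]2C[C@H]2N1C(=O)[C@H](O)c1ccccc1`: < 15 mL.min-1.g-1
Compound 2 `CC(C)(C)C[C@@H](O)C(=O)N1CC[C@@H]2C[C@@]21C(=O)NCc1cc(Cl)ccc1-n1cnnn1`: 27 mL.min-1.g-1

Compound 1 stands at < 15 mL.min-1.g-1 in this assay and this reading is a limit of the assay, not a number. Within the data shown here, compound 2, built on a different core, gives 27 mL.min-1.g-1 as the only true number so far.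

Compound 3 `CCCC[C@@H](O)C(=O)N1[C@@H]2C[C@@H]2C[C@H]1C(=O)NCc1cc(Cl)ccc1-n1cnnn1` keeps the core of compound 1 and changes one group. The change is butyl in place of phenyl on a saturated chain carbon bound to a carbonyl carbon and an oxygen on a saturated carbon and it replaces a ring with an open chain. Among the measured compounds shown here, no measured pair shows a change of this kind, so its size in this assay can only be expected. The expected step of an at least 1.4-fold higher number from compound 1 to compound 3 (0.16 log units; that floor lies within the scatter) runs towards faster clearance, modest in size and not firmly beyond the scatter, since it starts from a limit. For the measured compounds named here, the one number to lean on is that of compound 2 at 27 mL.min-1.g-1 and the expectation stays close to it. For compound 3 the estimated value is 22 mL.min-1.g-1 with an expected range from 11 mL.min-1.g-1 to 45 mL.min-1.g-1 in this assay as the read-out.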

Compound 3, intrinsic clearance in microsomes: 89 mL.min-1.g-1
Beside the measured number, compound 3's estimate is 4.0-fold (0.61 log units) below it; the measured number lies above the stated range.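

In this assay, the position on a saturated chain carbon bound to a carbonyl carbon and an oxygen on a saturated carbon now has its first measured change on the shared core: butyl in place of phenyl gives an at least 5.9-fold higher number from compound 1 to compound 3 (0.77 log units; beyond the scatter), a move towards faster clearance that lies beyond the scatter. Among these compounds, no earlier pair differed in one place, so compounds 1 and 2 alone could not show that the read-out responds to the group at this position, or that swapping a ring for an open chain here can produce a step of this size. The step is only a floor and its full size cannot be read, as the reading of compound 1 is a limit of the assay and not a number: the limit of < 15 mL.min-1.g-1 in this assay, at which 1 of the 3 values shown sits.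

The compounds shown leave open whether the step follows the loss of the ring or the presence of the butyl chain itself, a question that a cyclohexyl group at this position would help to separate. Going by these compounds, it also remains open how a shorter chain such as propyl, a longer chain, or an amine on the chain would read on this core.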